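This account rests on a few compounds, and the source may have more. Where it says the series, first, only, none or still open, it means among the compounds named here.

Measured compounds in a functional assay on RAW264.7 cells (Mus musculus) for inhibition, read by immunoassay, with a stated time of 12 h, tested at 30 uM; on this read-out lower numbers stand for less inhibition and higher numbers for more inhibition at the one concentration tested (going by the name of the read-out):
compound 1 `CCCOc1ccccc1C1CC(=O)c2ccccc2O1` — 45.7%
compound 2 `CC(C)COc1ccccc1C1CC(=O)c2ccccc2O1` — 30.4%
compound 3 `CCCCCOc1ccccc1C1CC(=O)c2ccccc2O1` — 41.3%

The three compounds share one core and differ only in the chain attached to the oxygen on an aromatic ring. Compound 3 stands second highest of the three numbers. Its nearest neighbour is compound 1: a number 4.4 percentage points lower from compound 1 to compound 3 (within the scatter). Its furthest is compound 2: a number 10.9 percentage points higher from compound 2 to compound 3 (beyond the scatter).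

Compound 4 `COCOc1ccccc1C1CC(=O)c2ccccc2O1` is not yet measured. It differs from compound 3 in one place: methoxy in place of butyl on a saturated chain carbon bound to an oxygen on an aromatic ring. All three measured steps change this same chain, so all bear on it. Two of them were modest, a number 15.3 percentage points lower from compound 1 to compound 2 (beyond the scatter) and a number 10.9 percentage points higher from compound 2 to compound 3 (beyond the scatter), and one stayed within the scatter, a number 4.4 percentage points lower from compound 1 to compound 3 (within the scatter). Changing the chain has so far moved the read-out by modest amounts at most, in either direction, so only a small shift is expected here, with a slight lean downward because a number 15.3 percentage points lower from compound 1 to compound 2 (beyond the scatter) shows that a branched, shorter chain gave less inhibition. Compound 4 is therefore expected to give 36%, with an estimated range from 20% to 52%. This estimate means a step of a number 5.3 percentage points lower from compound 3 to compound 4 (within the scatter).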

Compound 4, a percentage reported as inhibition, at one concentration (the size of the read-out at that concentration, not a potency): 35.2%
For compound 4 the middle estimate is 0.8 percentage points above the measured one; measured number inside the range.
By their numbers in this assay, from the lowest: compounds 2, 4, 3 and 1 (each within the scatter of the next, the first and the last beyond it).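

Compound 4 puts an oxygen into the chain, as methoxy, and in this assay this gives a number 6.1 percentage points lower from compound 3 to compound 4 (within the scatter) and a number 4.8 percentage points higher from compound 2 to compound 4 (within the scatter), with a modest change only in a number 10.5 percentage points lower from compound 1 to compound 4 (beyond the scatter). At this position, then, a chain holding an oxygen gives a number inside the range already set by the three all-carbon chains, and no step among these four compounds goes beyond modest. Nothing measured here accounts for these differences.

The compounds shown leave open whether a different kind of group on this oxygen, such as an amine, a carboxylic acid or a much longer chain, would move the read-out further. On these data alone, each number also comes from one concentration, so how these compounds compare in potency remains open.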